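Working notes: propyl to sec-butyl on the shared core

The source may report more compounds than this note shows. Statements on the series, on what has been measured and on what is new or still open speak of the compounds shown alone.

Compound 1 `CCCc1nc(C)c2c(C(C)C)nnc(S)n12` — in a functional assay for inhibition, with Homo sapiens as the target (on this read-out higher numbers stand for weaker inhibition and lower numbers for stronger inhibition), compound 1 gives > 48000 nM, a limit of the assay.
Compound 2 `CCc1nnc(O)n2c(C(C)CC)nc(C)c12` — in this assay compound 2 gives 45000 nM.
Compound 3 `CCCc1nc(C)c2c(CC)nnc(S)n12` — in this assay compound 3 gives > 48000 nM, again a limit of the assay.

Compound 3 therefore stands only at a limit and no number is known for it. Two of the three values shown sit at that same limit (the limit of > 48000 nM in this assay, at which 2 of the 3 values shown sit). Going by the values given here, the one measured step that reaches compound 3, a step that the two limits leave unreadable from compound 1 to compound 3, runs from one limit to another and its size cannot be read.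

Compound 4 `CCc1nnc(S)n2c(C(C)CC)nc(C)c12` is the next member. The change from compound 3 is methyl in place of hydrogen on a saturated chain carbon bound to an aromatic carbon and a saturated chain carbon. Among the compounds with values here, no measured step covers this change directly; the only step in hand is unreadable. Compound 2 carries the same sec-butyl and ethyl groups as compound 4, with hydroxyl in place of thiol, and compound 2 gives 45000 nM in this assay. Nothing in these numbers points to a shift in this assay beyond the scatter in either direction, so compound 4 is expected to remain weak and may well be reported as a limit again. The estimate for compound 4 in this assay is 60000 nM, within 30000 nM to 150000 nM. The expected step is a step that the limit leaves unreadable from compound 3 to compound 4, within the scatter.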

Compound 4, half-maximal inhibitory concentration: > 48000 nM
Compound 4 was reported as a limit; the forecaster's own chance of this, stated with the estimate: 70%; the middle value lies beyond the limit too.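

Compound 4 is a limit of the assay in this assay, at > 48000 nM, and the steps that run from limit to limit, including the one that adds methyl on a saturated chain carbon bound to an aromatic carbon and a saturated chain carbon, cannot be read. Going by these compounds alone, the pair with the same sec-butyl and ethyl groups gives the first partly readable comparison of sulfanyl in place of hydroxy on an aromatic carbon, an at least 1.0-fold higher number from compound 2 to compound 4 (0.02 log units; that floor lies within the scatter), which sets only a floor, and that floor shows no change beyond the scatter. The series therefore gains no measured effect of propyl to sec-butyl, and the sulfanyl compounds now rest at one shared limit: the limit of > 48000 nM in this assay, at which 3 of the 4 values shown sit.

On these data alone, how far compound 4 lies past its limit remains open, and with it the true size of the change from hydroxy to sulfanyl. Also open, as far as these compounds go, is whether an amine on that aromatic carbon, or a longer chain such as pentyl in place of sec-butyl, would give a number that can be read in this assay.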